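Removing a Chloro Group: Expected Effect on Cell Toxicity

The source may hold more compounds than are shown below. What is called first, only, known or untested is meant among the compounds shown, and "the series" means these compounds.

Measured compounds:
compound 1 `COc1ccc(OC)c(/C=C/c2nnc(Nc3ccc(Cl)cc3)o2)c1`: > 100000 nM
compound 2 `COc1ccc(OC)c(/C=C/C(=O)N/N=C/c2ccc(Cl)cc2)c1`: > 100000 nM

Of the compounds shown here, two have been tested in a functional assay on SK-MEL-28 cells (Homo sapiens) for antiproliferative activity, read by sulforhodamine B assay, with a stated time of 48 h; on this read-out higher numbers stand for lower toxicity in this test and lower numbers for higher toxicity in this test. Compound 1 gives > 100000 nM, which is a limit of the assay rather than a measured number. Compound 2 likewise gives > 100000 nM, again only a limit. So compound 2 stands nowhere on a scale of real numbers: both of the values shown are limits, as summarised by the limit of > 100000 nM in this assay, at which 2 of the 2 values shown sit. Among the measured compounds shown here, no step between measured compounds differing in one place is available, so no measured change can be pointed to.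

The new compound is compound 3 `COc1ccc(OC)c(/C=C/C(=O)N/N=C/c2ccccc2)c1`. It differs from compound 2 by hydrogen in place of chloro on an aromatic carbon. With both known values sitting at the limit, the step from compound 2 to compound 3 is expected to be none beyond the usual scatter, which in terms of the estimate means a number no higher from compound 2 to compound 3 (the limit leaves the size open). Compound 3 is therefore expected to give about 100000 nM in this assay, with a plausible range from 30000 nM to 300000 nM, most likely again reported only as a limit.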

Compound 3, concentration lethal to 50% of the cells: > 100000 nM
Compound 3: only a limit was reported (the forecaster's own chance of this, stated with the estimate: 75%); the middle value sits exactly at the limit.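

In this assay compound 3 gives > 100000 nM, which is a limit of the assay and not a number. Compound 2 also sits at a limit, so no step can be read between compound 2 and compound 3. The compounds shown leave open whether hydrogen in place of chloro changes toxicity in this test at all.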